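Thiadiazole to tetrazole swap on the sulfur-linked naphthol amides

The source may report more compounds than this note shows. Statements on the series, on what has been measured and on what is new or still open speak of the compounds shown alone.

Measured so far:
compound 1 `Cc1nnc(Sc2cc(NC(=O)c3ccc(Cl)cc3)c3ccccc3c2O)s1` gives 8.48% in an assay on isolated protein for inhibition of RAC-alpha serine/threonine-protein kinase (Homo sapiens), read by fluorescence, with a stated time of 30 min, tested at 10 uM; a higher number here means more inhibition at the concentration tested (going by the name of the read-out), a lower number less inhibition
compound 2 `O=C(Nc1cc(Sc2ncn[nH]2)c(O)c2ccccc12)c1cccc(Cl)c1` gives 46% in this assay

Compound 1 stands lowest of the two numbers in this assay; the nearest is compound 2, whose number lies above it by a gap that is beyond the usual scatter. For the measured compounds named here, compound 2 differs from compound 1 in more than one place, so the two values show only that the pair sits apart; no single structural step between them is recorded.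

The step now followed leads from compound 1 to compound 3 `Cn1nnnc1Sc1cc(NC(=O)c2ccc(Cl)cc2)c2ccccc2c1O`. The change is 1-methyl-1H-tetrazol-5-yl in place of 5-methyl-1,3,4-thiadiazol-2-yl on a sulfur. Both groups sit on a sulfur whose other neighbour is an aromatic carbon, and both are five-membered aromatic rings carrying a methyl; the difference is one more nitrogen in the ring and one more acceptor.

Going by the values given here, with no step between measured compounds to lean on, the expectation for compound 3 is a step of a number 5.5 percentage points higher from compound 1 to compound 3 (within the scatter) that stays within, or barely at, the scatter, if anything upward. Compound 3 is estimated at 14%, with a range from 0% to 38%.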

Compound 3, a percentage reported as inhibition, at one concentration (the size of the read-out at that concentration, not a potency): 13.1%
Compound 3: the middle estimate sits 0.9 percentage points above what was measured; the range from low to high includes it.
By their numbers in this assay, from the lowest: compounds 1 and 3 (each within the scatter of the next); then compound 2.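

For the compounds shown here, putting 1-methyl-1H-tetrazol-5-yl in place of 5-methyl-1,3,4-thiadiazol-2-yl on a sulfur gives, in this assay, a number 4.6 percentage points higher from compound 1 to compound 3 (within the scatter), the first reading of a change at one place. At this position, two five-membered aromatic rings with the same heavy-atom count, each carrying a methyl, therefore cannot be told apart by this read-out, even though they differ in ring hetero atoms and hydrogen-bond acceptors. No measured property of either group is available that bears on this result.

From the compounds shown here alone, compound 2, at 46%, differs from both compound 1 and compound 3 in more than one place, so no single structural change can be credited with its separate value, and whether the ring on the sulfur contributes to it remains open. Also open, going by these compounds, is whether a sulfur-linked ring bearing an amine or a carboxylic acid in place of the methyl would move the number beyond the scatter, since both rings read so far carry only a methyl.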